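Aromatic substituent swaps on a urea series: methoxy to acetyl

This account rests on a few compounds, and the source may have more. Where it says the series, first, only, none or still open, it means among the compounds named here.

The three measured compounds share one core and differ only in the group on the aromatic ring that carries the urea nitrogen. Compound 1 `CCc1ccccc1NC(=O)N[C@@H](C)c1ccccc1` gives 100% in an ADME assay on the whole organism with Oryza sativa as the target, tested at 0.1 uM; on this read-out higher numbers stand for a weaker effect at the one concentration tested and lower numbers for a stronger effect. Compound 2 `CC(C)c1ccccc1NC(=O)N[C@@H](C)c1ccccc1` gives 99%, and compound 3 `COc1ccccc1NC(=O)N[C@@H](C)c1ccccc1` gives 98%. None of these separates from the others: the step of a number 1 percentage points lower from compound 1 to compound 2 (within the scatter), the step of a number 2 percentage points lower from compound 1 to compound 3 (within the scatter) and the step of a number 1 percentage points lower from compound 2 to compound 3 (within the scatter) are all within the scatter, so compound 3 sits together with compounds 1 and 2 at the weak end of the read-out.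

Compound 4 `CC(=O)c1ccccc1NC(=O)N[C@@H](C)c1ccccc1` has not been measured. Relative to compound 3 the change is acetyl in place of methoxy on an aromatic carbon. Within the data shown here, two measured steps bear on it, both swaps of the group on this aromatic carbon: from ethyl to methoxy, a number 2 percentage points lower from compound 1 to compound 3 (within the scatter), and from isopropyl to methoxy, a number 1 percentage points lower from compound 2 to compound 3 (within the scatter). Neither moved the number beyond the scatter, and acetyl enters at the same place. The expectation is therefore a step of about a number 1 percentage points lower from compound 3 to compound 4 (within the scatter), that is no movement beyond the scatter.

Compound 4 is expected to give about 97%, estimated between 88% and 100%.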

Compound 4, a percentage reported as activity, at one concentration (the size of the read-out at that concentration, not a potency): 100%
Compound 4: middle estimate off by 3 percentage points, on the low side, and the stated range covers the measured number.
By their numbers in this assay, from the lowest: compounds 3, 2, 1 and 4 (each within the scatter of the next).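

In this assay the entry of acetyl on this aromatic carbon gives a number 2 percentage points higher from compound 3 to compound 4 (within the scatter) and a number 1 percentage points higher from compound 2 to compound 4 (within the scatter) and also no change at the digits printed from compound 1 to compound 4 (within the scatter) and this read-out therefore does not part acetyl from methoxy, isopropyl or ethyl. The earlier compounds shown here placed only saturated carbon groups and methoxy here, whereas acetyl brings a carbonyl, the double bond outside aromatic rings counted for this change, and the values of all four compounds still lie within the scatter of one another. No supporting data are available to explain why this position stays flat across the four groups.

It remains open whether any group on this aromatic carbon can move the number beyond the scatter, since an amine, a carboxylic acid, a halogen such as chlorine or a longer chain such as butyl does not appear among the compounds shown. Also open, as far as these compounds go, is whether changes elsewhere on the shared core, such as replacing the methyl on the saturated carbon with ethyl, would separate compounds that sit together here at the single concentration tested.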